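This account rests on a few compounds, and the source may have more. Where it says the series, first, only, none or still open, it means among the compounds named here.

Working notes on the series. Compound 1 (`CCC(CO)(CO)C(=O)Oc1ccc(/C=C/C(=O)/C=C(O)/C=C/c2ccc(O)c(OC)c2)cc1OC`) gives 4660 nM in a functional assay on MDA-MB-231 cells (Homo sapiens) for antiproliferative activity, read by MTT assay, with a stated time of 72 h (a higher number here means a weaker inhibitor, a lower number a stronger inhibitor), and compound 2 (`CC(CO)(CO)C(=O)Oc1ccc(/C=C/C(=O)/C=C(O)/C=C/c2ccc(OC(=O)C(C)(CO)CO)cc2)cc1`) gives 6740 nM in the same test, so the two values lie within the scatter of each other. Compound 3 (`CC(CO)(CO)C(=O)Oc1ccc(/C=C/C(=O)/C=C(O)/C=C/c2ccc(O)cc2)cc1`) differs from compound 2 by one change: hydrogen in place of (1,1-bis(hydroxymethyl)ethyl)carbonyl on an oxygen on an aromatic ring. Going by the values given here, no measured pair shows this change, so no step beyond the scatter is expected in this assay. The expected change is a 1.3-fold lower number from compound 2 to compound 3 (0.13 log units; within the scatter) and remains small. Compound 3 is estimated at 5000 nM (expected range 2200 nM to 11000 nM).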

Compound 3, half-maximal inhibitory concentration: 1330 nM
The estimate for compound 3 lay 3.8-fold (0.58 log units) above the measured number; measured number outside the range, below it.
By their numbers in this assay, from the lowest: compound 3; then compounds 1 and 2 (each within the scatter of the next).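

Placing hydrogen in place of (1,1-bis(hydroxymethyl)ethyl)carbonyl on an oxygen on an aromatic ring gives a 5.1-fold lower number from compound 2 to compound 3 (0.70 log units; beyond the scatter) in this assay. Going by these compounds alone, this is the only step beyond the scatter, and it shows that this position responds to the change, which the values of compound 1 and compound 2 alone could not show. No measurement available bears on the reason for the step. Still open, as far as these compounds go, is whether a smaller acetyl or a methyl on this oxygen would keep the lower number, and whether removing the same group from the other aromatic ring would give a similar step.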